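The source may report more compounds than this note shows. Statements on the series, on what has been measured and on what is new or still open speak of the compounds shown alone.

Compound 2 `COc1cc(Nc2nc3ccccc3nc2S(=O)(=O)c2ccc(C)cc2)cc(OC)c1` sits second highest of the three numbers in a functional assay on PC-3 cells (Homo sapiens) for cytotoxicity, read by MTT assay, with a stated time of 72 h (a lower number here means a stronger inhibitor, a higher number a weaker inhibitor), where compound 2 gives 2940 nM. Its nearest neighbour is compound 3 `COc1cc(Nc2nc3ccccc3nc2S(=O)(=O)c2ccc(C)cc2)cc(OC)c1OC`, which gives 4850 nM, a step of a 1.6-fold higher number from compound 2 to compound 3 (0.22 log units; within the scatter) that is within the scatter. Furthest is compound 1 `COc1cc(Nc2nc3ccccc3nc2S(=O)(=O)c2ccccc2)cc(OC)c1`, which gives 140 nM; the step of a 21-fold higher number from compound 1 to compound 2 (1.32 log units; beyond the scatter) is large and beyond the scatter. Compound 4 `Cc1ccc(S(=O)(=O)c2nc3ccccc3nc2Nc2cccc(O)c2)cc1` differs from compound 2 by 3-hydroxyphenyl in place of 3,5-dimethoxyphenyl on a nitrogen on an aromatic ring. Neither measured step touches this change directly: the step from compound 1 to compound 2 alters the sulfonyl-bearing ring, and the step from compound 2 to compound 3 adds a methoxy to the ring that is here replaced wholesale. Only the latter bears on the same ring, and it was small. Going by the values given here, with no closer precedent, the expected step in this assay, a 1.4-fold higher number from compound 2 to compound 4 (0.13 log units; within the scatter), is judged modest and uncertain in direction. Compound 4 is therefore estimated at 4000 nM, with a range from 1000 nM to 16000 nM.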

Compound 4, half-maximal inhibitory concentration: 1690 nM
The estimate for compound 4 lay 2.4-fold (0.37 log units) above the measured number; low and high end bracket the measured number.
By their numbers in this assay, from the lowest: compound 1; then compounds 4, 2 and 3 (each within the scatter of the next, the first and the last beyond it).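

In this assay the exchange of 3,5-dimethoxyphenyl for 3-hydroxyphenyl on the nitrogen gives a 1.7-fold lower number from compound 2 to compound 4 (0.24 log units; within the scatter) and so stays within the scatter, as does the added methoxy in a 1.6-fold higher number from compound 2 to compound 3 (0.22 log units; within the scatter) on the same ring. With the methyl-bearing sulfonyl ring held fixed, this group went from 10 heavy atoms to 7 and from 0 hydrogen-bond donors to 1 without a step beyond the scatter, whereas a 21-fold higher number from compound 1 to compound 2 (1.32 log units; beyond the scatter) on the sulfonyl-bearing ring remains the only large step shown. No available evidence explains why this exchange makes so little difference.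

The compounds shown leave open whether 3-hydroxyphenyl would read the same on the sulfonyl-bearing ring of compound 1, which lacks the methyl. They also leave open what an amine or a carboxylic acid in place of the hydroxy would do.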